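The source may hold more compounds than are shown below. What is called first, only, known or untested is meant among the compounds shown, and "the series" means these compounds.

Measured in a toxicity assay on CCRF-CEM cells (Homo sapiens) for cytotoxicity; a higher number here means that more compound is tolerated, a lower number that less compound is tolerated:

Compound 1 `Oc1cccc2c1nc(-c1c(F)cccc1F)n2Cc1c(F)cccc1F`: > 100 uM, a limit of the assay.
Compound 2 `CC(=O)N(C)c1cccc2c1nc(-c1c(F)cccc1F)n2Cc1c(F)cccc1F`: > 100 uM, a limit of the assay.
Compound 3 `CNc1cccc2c1nc(-c1c(F)cccc1F)n2Cc1c(F)cccc1F`: 27.2 uM.

Among these three, compound 3 alone has a true number, 27.2 uM. The other two stand at the limit of > 100 uM in this assay, at which 2 of the 3 values shown sit, so compound 3 is the least tolerated of the set, though only against limits.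

The next compound, compound 4 `CC(C)=CCc1cccc2c1nc(-c1c(F)cccc1F)n2Cc1c(F)cccc1F`, carries 3-methylbut-2-en-1-yl in place of methylamino on an aromatic carbon.

Among the measured compounds shown here, two measured steps bear on this change, since each alters the same substituent. They are an at least 3.6-fold lower number from compound 1 to compound 3 (0.56 log units; beyond the scatter) and an at least 3.6-fold lower number from compound 2 to compound 3 (0.56 log units; beyond the scatter). As far as these compounds go, both are at least modest, and both are open-ended, so their true sizes are unknown. The third step, a step that the two limits leave unreadable from compound 1 to compound 2, adds nothing on size. These steps show that the number in this assay can move with the group at this place, but none of the compounds carries a carbon chain there, so the direction for compound 4 is uncertain.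

A move back towards the limit seems somewhat more likely than a further fall, and a report as a limit alone is possible. The expected change is a 1.5-fold higher number from compound 3 to compound 4 (0.17 log units; within the scatter), with no firm step beyond the scatter anticipated. For compound 4 the estimated value is 40 uM, with an expected range from 13 uM to 100 uM.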

Compound 4, half-maximal toxic concentration: 28.3 uM
The estimate for compound 4 lay 1.4-fold (0.15 log units) above the measured number, within the range that was stated.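

In this assay, the exchange gave a 1.0-fold higher number from compound 3 to compound 4 (0.02 log units; within the scatter), so 3-methylbut-2-en-1-yl, a carbon chain with no hydrogen-bond donor or acceptor, gives a number that cannot be told apart from that of methylamino on this aromatic carbon. Among the compounds shown here, no earlier compound could show this. None of them carried a carbon chain here. The new compound also separates from the two compounds without a true number, with an at least 3.5-fold lower number from compound 2 to compound 4 (0.54 log units; beyond the scatter) and an at least 3.5-fold lower number from compound 1 to compound 4 (0.54 log units; beyond the scatter), so the drop from those compounds is no longer tied to methylamino alone but is shared by a group that holds no nitrogen. The values of compound 1 and compound 2 are each a limit of the assay, so the step between them cannot be read and the full sizes of their steps to the other two compounds stay unknown: the limit of > 100 uM in this assay, at which 2 of the 4 values shown sit.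

The compounds shown leave open whether a shorter ethyl chain, a saturated chain or a primary amine on this carbon would stay level with compound 3 and compound 4. They also leave open whether a carboxylic acid here would return the number to the limit, as hydroxy and acetyl(methyl)amino do.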